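Swapping cyclopropyl for phenyl on a carbonyl carbon

The source may report more compounds than this note shows. Statements on the series, on what has been measured and on what is new or still open speak of the compounds shown alone.

Compound 1 `CCCCNC(=O)N1Cc2c(NC(=O)c3ccccc3)nn(C(=O)c3ccccc3)c2C1` gives 7470 nM
Compound 2 `CCCCNC(=O)N1Cc2c(NC(=O)c3ccc(C)cc3)nn(C(=O)C3CC3)c2C1` gives 17600 nM

In a functional assay on HCT-116 cells (Homo sapiens) for cytotoxicity, read by sulforhodamine B assay, with a stated time of 48 h (a lower number here means a stronger inhibitor, a higher number a weaker inhibitor), compound 2 has the higher of the two numbers (17600 nM), which makes it the weaker of the pair. Compound 1 sits lower (7470 nM), and the gap lies beyond the usual scatter. These two compounds differ in more than one place, so they do not isolate any single change.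

Compound 3 `CCCCNC(=O)N1Cc2c(NC(=O)c3ccc(C)cc3)nn(C(=O)c3ccccc3)c2C1` departs from compound 2 in one place: phenyl in place of cyclopropyl on a carbonyl carbon. Compound 1 (7470 nM) carries the same phenyl there, so a modest move to a lower number is expected in this assay. The step expected is a 2.1-fold lower number from compound 2 to compound 3 (0.32 log units; beyond the scatter) (an estimate only). Compound 3 is estimated at 8500 nM (range 3500 nM to 19000 nM).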

Compound 3, half-maximal inhibitory concentration: 23200 nM
For compound 3 the middle estimate is 2.7-fold (0.44 log units) below the measured one; the measured number lies above the stated range.
By their numbers in this assay, from the lowest: compound 1; then compounds 2 and 3 (each within the scatter of the next).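

In this assay, phenyl in place of cyclopropyl on a carbonyl carbon whose other neighbour is an aromatic nitrogen leaves the number within the scatter (a 1.3-fold higher number from compound 2 to compound 3 (0.12 log units; within the scatter)), so this pair does not tell cyclopropylcarbonyl and benzoyl apart. The change that does exceed the scatter is methyl in place of hydrogen on an aromatic carbon, with benzoyl held fixed (a 3.1-fold higher number from compound 1 to compound 3 (0.49 log units; beyond the scatter)). Nothing available here explains either result.

From the compounds shown here alone, it remains open whether a group of another kind on this carbonyl carbon, such as a longer carbon chain or an amine, would shift the number. Going by these compounds, it is also open whether chlorine or methoxy in place of that methyl would give a step of similar size.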